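Replacing the dimethylcarbamoyl group of compound 3

The compounds below may be only part of what the source reports. "The series", "measured", "known", "first", "only" and "open" are said of these compounds alone.

In a functional assay (aorta) with Rattus norvegicus as the target (a lower number here means that less compound is needed, a higher number that more compound is needed for the effect), compound 3 `COc1ccc(-c2nc(C(=O)N(C)C)sc2-c2ccc(OC)cc2)cc1` gives 3 uM, the middle of the three numbers available. Compound 1 `CNC(=N)Nc1nc(-c2ccc(OC)cc2)c(-c2ccc(OC)cc2)s1` stands lower at 1.2 uM, and compound 2 `COc1ccc(-c2nc(CNC(=O)c3cccnc3)sc2-c2ccc(OC)cc2)cc1` stands higher at 8.2 uM. Compound 4 `CCOC(=O)/C=C/c1nc(-c2ccc(OC)cc2)c(-c2ccc(OC)cc2)s1` awaits measurement. It carries 2-(ethoxycarbonyl)ethenyl in place of dimethylcarbamoyl on an aromatic carbon of a five-membered aromatic ring with 1 nitrogen and 1 sulfur (2-(ethoxycarbonyl)ethenyl in place of dimethylcarbamoyl on an aromatic carbon). All three measured steps change the group at this same place: a 2.5-fold higher number from compound 1 to compound 3 (0.40 log units; beyond the scatter), a 2.7-fold lower number from compound 2 to compound 3 (0.44 log units; beyond the scatter) and a 6.8-fold higher number from compound 1 to compound 2 (0.83 log units; beyond the scatter). Each is modest, although the groups exchanged differ widely. Among the compounds with values here, no measured compound carries the entering group, so the data show no direction for this change. Only a modest step is therefore expected, and neither direction is favoured. The estimated step is a 1.3-fold higher number from compound 3 to compound 4 (0.12 log units; within the scatter), which is not expected to exceed the scatter. For compound 4 the estimate is 4 uM, with an expected range from 1.3 uM to 12 uM.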

Compound 4, concentration for half-maximal effect: > 100 uM
Compound 4: only a limit was reported; the forecaster's own chance of this, stated with the estimate: 5%; middle value at least 25-fold (1.39 log units) from the limit.
By their numbers in this assay, from the lowest: compound 1; then compound 3; then compound 2. At a limit, above all of these: compound 4.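

Compound 4 gives no number in this assay, only a limit of the assay: the limit of > 100 uM in this assay, at which 1 of the 4 values shown sits. Exchanges at this aromatic carbon had so far produced only modest steps, but 2-(ethoxycarbonyl)ethenyl produces large ones: an at least 33-fold higher number from compound 3 to compound 4 (1.52 log units; beyond the scatter), an at least 12-fold higher number from compound 2 to compound 4 (1.08 log units; beyond the scatter) and an at least 83-fold higher number from compound 1 to compound 4 (1.92 log units; beyond the scatter). The position is therefore less permissive than compounds 1, 2 and 3 suggested, as the wide variety of groups in those compounds does not extend to every group placed here.

The compounds shown do not separate the contribution of the ethenyl link from that of the ethyl ester, which a saturated ethyl chain bearing the same ester or a carboxylic acid in place of the ester could address. From the compounds shown here alone, how large the steps to compound 4 really are also stays open, as only a limit is available.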